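Aryl group variation on the enone carbon: compound 4

A few compounds are considered here, and "the series" means these few. Any claim that something is new, unique, unknown or untested is made for them only; others in the source may bear on it.

Compound 3 `COc1cc(C2=CC(=O)N3C[C@H](O[C@H](C)c4cc(C(F)(F)F)cc(C(F)(F)F)c4)[C@@H](c4ccc(F)cc4)C3C2)ccn1` gives 1.1 nM in an assay on CHO cells for displacement of a labelled ligand from Substance-P receptor (Homo sapiens); a higher number here means a weaker inhibitor, a lower number a stronger inhibitor; on this number it sits highest of the three. Compound 1 `C[C@@H](O[C@H]1CN2C(=O)C=C(c3ccc(NS(C)(=O)=O)cc3)CC2[C@@H]1c1ccc(F)cc1)c1cc(C(F)(F)F)cc(C(F)(F)F)c1` gives 1 nM, and the gap between compound 1 and compound 3 lies within the scatter. Compound 2 `C[C@@H](O[C@H]1CN2C(=O)C=C(c3ccc(CO)cc3)CC2[C@@H]1c1ccc(F)cc1)c1cc(C(F)(F)F)cc(C(F)(F)F)c1` gives 0.39 nM, and the gap between compound 2 and compound 3 exceeds the scatter. Compound 4 `C[C@@H](O[C@H]1CN2C(=O)C=C(c3cc[nH]c(=O)c3)CC2[C@@H]1c1ccc(F)cc1)c1cc(C(F)(F)F)cc(C(F)(F)F)c1` carries the change (a group of 7 heavy atoms (5 carbon, 1 nitrogen, 1 oxygen; one six-membered aromatic ring with 1 hetero atom) in place of a group of 8 heavy atoms (6 carbon, 1 nitrogen, 1 oxygen; one six-membered aromatic ring with 1 hetero atom), on a double-bonded ring carbon), so a group with one hydrogen-bond donor and one acceptor replaces one with two acceptors and no donor. The measured steps at this same position are a 1.1-fold higher number from compound 1 to compound 3 (0.04 log units; within the scatter), a 2.8-fold higher number from compound 2 to compound 3 (0.45 log units; beyond the scatter) and a 2.6-fold lower number from compound 1 to compound 2 (0.41 log units; beyond the scatter); compound 2, whose group carries a donor, gives the lowest number. A modest downward step is therefore expected for compound 4, a 1.4-fold lower number from compound 3 to compound 4 (0.14 log units; within the scatter), near the edge of the scatter. Compound 4 is estimated at 0.8 nM, range 0.3 nM to 2.5 nM.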

Compound 4, half-maximal inhibitory concentration: 0.27 nM
Beside the measured number, compound 4's estimate is 3.0-fold (0.47 log units) above it, and the stated range ends above it.
By their numbers in this assay, from the lowest: compounds 4 and 2 (each within the scatter of the next); then compounds 1 and 3 (each within the scatter of the next).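

In this assay the change to the new group gives a 4.1-fold lower number from compound 3 to compound 4 (0.61 log units; beyond the scatter) beyond the scatter, so replacing 2-methoxypyridin-4-yl here is not neutral, although replacing the methanesulfonamido-bearing phenyl with that pyridine was. The new group also gives a 3.7-fold lower number from compound 1 to compound 4 (0.57 log units; beyond the scatter) beyond the scatter, while a 1.4-fold lower number from compound 2 to compound 4 (0.16 log units; within the scatter) stays within it, so two quite different groups with a hydrogen-bond donor match here, though compound 1 goes against any simple donor link. No available evidence bears on the reason for these steps. Still open, as far as these compounds go, is whether an amine or a carboxylic acid on this double-bonded ring carbon would match these values.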